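The source may hold more compounds than are shown below. What is called first, only, known or untested is meant among the compounds shown, and "the series" means these compounds.

Compound 2 `CCCOC(=O)c1[nH]c(C(=O)NCC2CC2)c(C(=O)OC(C)(C)C)c1C` gives 2500 nM in an assay on CHO cells for inhibition of metabotropic glutamate receptor 1 (Rattus norvegicus) (a higher number here means a weaker inhibitor, a lower number a stronger inhibitor), and compound 1 `CCCOC(=O)c1[nH]c(COC(C)=O)c(C(=O)OC(C)(C)C)c1C` gives 2700 nM, so the two sit within the scatter of each other. The step of a 1.1-fold lower number from compound 1 to compound 2 (0.03 log units; within the scatter) is the only measured one on this site. Compound 3 `CCCOC(=O)c1[nH]c(CO)c(C(=O)OC(C)(C)C)c1C` carries the change (hydroxymethyl in place of (cyclopropylmethyl)carbamoyl on an aromatic carbon). That one step, being within the scatter, suggests the group on this aromatic carbon barely moves the number, so compound 3 is expected to show no step beyond the scatter, a 1.3-fold higher number from compound 2 to compound 3 (0.11 log units; within the scatter). Compound 3 is therefore estimated at 3200 nM, with a range from 1200 nM to 9000 nM.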

Compound 3, half-maximal inhibitory concentration: 7900 nM
Estimate against measurement, compound 3: 2.5-fold (0.39 log units) below; the range from low to high includes it.
By their numbers in this assay, from the lowest: compounds 2 and 1 (each within the scatter of the next); then compound 3.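

In this assay the group on this aromatic carbon does move the number: hydroxymethyl in place of (cyclopropylmethyl)carbamoyl gives a 3.2-fold higher number from compound 2 to compound 3 (0.50 log units; beyond the scatter) and hydrogen in place of acetyl on the oxygen gives a 2.9-fold higher number from compound 1 to compound 3 (0.47 log units; beyond the scatter) as well, both modest steps beyond the scatter. Acetoxymethyl and (cyclopropylmethyl)carbamoyl remain within the scatter of each other, while hydroxymethyl alone stands apart from both.

On these data alone, whether an amine or a carboxylic acid on this carbon would fall with compound 2 or with compound 3 stays open. No evidence is at hand on what lies behind these steps.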